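One Methoxy Group Fewer: What Compound 4 May Show

The source may report more compounds than this note shows. Statements on the series, on what has been measured and on what is new or still open speak of the compounds shown alone.

Compound 1 `COc1ccc(-c2nc3cc([N+](=O)[O-])ccc3[nH]2)c(OC)c1OC` was tested in a functional assay on aorta (Rattus norvegicus, strain Wistar) for inhibition, with a stated time of 60 min (on this read-out lower numbers stand for smaller maximal responses and higher numbers for larger maximal responses), where compound 1 gives 90%. This is the highest of the three numbers in hand, though neither of the others lies beyond the scatter of it: compound 3 `CCOc1ccccc1-c1nc2cc([N+](=O)[O-])ccc2[nH]1` gives 84.8%, and compound 2 `CC(C)Oc1ccccc1-c1nc2cc([N+](=O)[O-])ccc2[nH]1` gives 80.7%. Compound 4 `COc1ccc(-c2nc3cc([N+](=O)[O-])ccc3[nH]2)cc1OC` has not yet been measured. It differs from compound 1 in one place, (hydrogen in place of methoxy on an aromatic carbon). Going by the values given here, the only measured step that bears on such a change, a shortening of a group bound through an oxygen on the aromatic ring, is a number 4.1 percentage points higher from compound 2 to compound 3 (within the scatter), a step that stayed within the scatter. Among the compounds with values here, no measured pair removes a methoxy group outright, so the record gives little direct guidance. On that basis a step within the scatter is expected, with compound 4 estimated to reach 85%, between 70% and 97%. That estimate amounts to an expected step of a number 5 percentage points lower from compound 1 to compound 4 (within the scatter).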

Compound 4, largest response reached (Emax), in percent of the reference or control that the assay uses: 75%
Estimate against measurement, compound 4: 10 percentage points above; measured number inside the range.
By their numbers in this assay, from the lowest: compounds 4, 2, 3 and 1 (each within the scatter of the next, the first and the last beyond it).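

In this assay, putting hydrogen in place of this one methoxy group gives the first step among the compounds shown that lies beyond the scatter (a number 15 percentage points lower from compound 1 to compound 4 (beyond the scatter)). The read-out therefore responds to a change on this aromatic carbon, ortho to a large group and ortho to a methoxy group, which the earlier step on a group bound through oxygen did not show, as that step stayed within the scatter (a number 4.1 percentage points higher from compound 2 to compound 3 (within the scatter)). Nothing at hand accounts for this loss of a methoxy group.

The compounds shown leave open whether a hydroxyl group, a fluorine atom or an amine on this carbon would stay nearer compound 1 or compound 4, and what a longer chain in place of the methoxy group would do. They also leave open whether removing either of the other two methoxy groups would give a step of similar size.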